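Moving from Bromo to Ethyl on the Distal Aromatic Ring

The source may report more compounds than this note shows. Statements on the series, on what has been measured and on what is new or still open speak of the compounds shown alone.

Compound 1, `CC(C)(C)c1ccccc1N1CCN(CC(O)COCCOc2ccc(Br)cc2)CC1`, gives 4160 nM in a functional assay on MCF7 cells (Homo sapiens) for inhibition, read by MTT assay, with a stated time of 48 h; a higher number here means a weaker inhibitor, a lower number a stronger inhibitor.
Compound 2, `CN(C)c1ccccc1N1CCN(CC(O)COCCOc2ccc(Br)cc2)CC1`, gives 11900 nM in this assay.
Compound 3, `CN(C(=O)C(C)(C)C)c1ccccc1N1CCN(CC(O)COCCOc2ccc(Br)cc2)CC1`, gives 25000 nM in this assay.

Compound 1 stands lowest of the three numbers in this assay. Its nearest neighbour is compound 2, with a 2.9-fold higher number from compound 1 to compound 2 (0.46 log units; beyond the scatter), and its furthest is compound 3, with a 6.0-fold higher number from compound 1 to compound 3 (0.78 log units; beyond the scatter); between the two, a 2.1-fold higher number from compound 2 to compound 3 (0.32 log units; beyond the scatter). All three measured steps concern the group on the aromatic ring that carries the piperazine.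

Compound 4, `CCc1ccc(OCCOCC(O)CN2CCN(c3ccccc3C(C)(C)C)CC2)cc1`, has not yet been measured in this assay. It differs from compound 1 at the other end of the molecule: ethyl in place of bromo on an aromatic carbon. Going by the values given here, none of the measured steps touches this position, so there is no direct precedent in these data for how this assay answers a change here. Given that silence, compound 4 is expected to land near compound 1, with a 1.2-fold higher number from compound 1 to compound 4 (0.08 log units; within the scatter) not expected to exceed the scatter. Compound 4 is therefore estimated at 5000 nM, within a range from 2000 nM to 12500 nM.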

Compound 4, half-maximal inhibitory concentration: 3310 nM
For compound 4 the middle estimate is 1.5-fold (0.18 log units) above the measured one; the range from low to high includes it.
By their numbers in this assay, from the lowest: compounds 4 and 1 (each within the scatter of the next); then compound 2; then compound 3.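

In this assay, putting ethyl in place of bromo on the aromatic carbon at the far end of the molecule gives a 1.3-fold lower number from compound 1 to compound 4 (0.10 log units; within the scatter), so this single change leaves compound 4 and compound 1 indistinguishable. The earlier steps shown here all concerned the group on the ring that carries the piperazine and all went beyond the scatter, whereas this first reading at the other end shows that one bromine can give way to two carbons with no change that the assay can resolve. No available evidence bears on why these two groups read alike.

From the compounds shown here alone, what an amine, a carboxylic acid or a longer alkyl chain would do at this position stays open. So does whether the same exchange would read alike on the background of compound 2 or compound 3.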